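A Dimethylphenyl Swap on a Sulfonamide Scaffold

The source may report more compounds than this note shows. Statements on the series, on what has been measured and on what is new or still open speak of the compounds shown alone.

Compound 1 `O=C1NCCN1c1ccc(S(=O)(=O)Nc2ccc(I)cc2)cc1` gives 650 nM in a functional assay on HT-29 cells (Homo sapiens) for antiproliferative activity, read by sulforhodamine B assay, with a stated time of 48 h (on this read-out higher numbers stand for weaker inhibition and lower numbers for stronger inhibition), the higher of the two numbers shown; compound 3 `CCCCOc1ccc(NS(=O)(=O)c2ccc(N3CCNC3=O)cc2)cc1` sits nearest with 630 nM, a gap within the scatter. Compound 2 `CC(C)(C)c1ccc(NS(=O)(=O)c2ccc(N3CCNC3=O)cc2)cc1` reaches only the limit of > 1000 nM in this assay (the limit of > 1000 nM in this assay, at which 1 of the 3 values shown sits). Two measured steps start from compound 1: an at least 1.5-fold higher number from compound 1 to compound 2 (0.18 log units; that floor lies within the scatter), and a 1.0-fold lower number from compound 1 to compound 3 (0.01 log units; within the scatter). Compound 4 `Cc1cccc(NS(=O)(=O)c2ccc(N3CCNC3=O)cc2)c1C` differs from compound 1 by 2,3-dimethylphenyl in place of 4-iodophenyl on a sulfonamide nitrogen. Neither measured step involves this group, and both stay within the scatter, so no step beyond the scatter is expected, with a slight lean toward a higher number. For compound 4 the expected value is 800 nM (range 300 nM to 2500 nM), an expected step of a 1.2-fold higher number from compound 1 to compound 4 (0.09 log units; within the scatter).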

Compound 4, half-maximal inhibitory concentration: 190 nM
Estimate against measurement, compound 4: 4.2-fold (0.62 log units) above; measured number outside the range, below it.
By their numbers in this assay, from the lowest: compound 4; then compounds 3 and 1 (each within the scatter of the next). At a limit, above all of these: compound 2.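

Changing the aromatic group on the sulfonamide nitrogen can move this read-out beyond the scatter: in this assay, 2,3-dimethylphenyl in place of 4-iodophenyl gives a 3.4-fold lower number from compound 1 to compound 4 (0.53 log units; beyond the scatter). None of the earlier steps was shown to exceed the scatter, so this is the first clear sign that this position can yield stronger inhibition. Nothing measured here explains why this change has that effect.

It remains open whether both methyl groups are needed, since a phenyl carrying a single methyl is not among the compounds shown. On these data alone, how a chloro group or a pyridine ring would fare at this position also remains open.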